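The source may report more compounds than this note shows. Statements on the series, on what has been measured and on what is new or still open speak of the compounds shown alone.

Compound 1 `O=C(CCCCCN1C(=O)CC(SCCOCCOCCOc2cc(O)c(C(=O)CCc3ccc(O)cc3)c(O)c2)C1=O)OCn1cc(F)c(=O)[nH]c1=O` gives 75000 nM.
Compound 2 `O=C(CCCc1cn(CCOCCOCCOc2cc(O)c(C(=O)CCc3ccc(O)cc3)c(O[C@@H]3O[C@H](CO)[C@@H](O)[C@H](O)[C@H]3O)c2)nn1)OCn1cc(F)c(=O)[nH]c1=O` gives > 100000 nM.

Both compounds were tested in a functional assay on HCT-116 cells (Homo sapiens) for cytotoxicity, read by sulforhodamine B assay, with a stated time of 48 h; a lower number here means a stronger inhibitor, a higher number a weaker inhibitor. Compound 1 gives a measured value of 75000 nM. For compound 2 the result is only a limit of the assay, > 100000 nM, not a number; the fact that one of the two values sits at this limit is summed up in the limit of > 100000 nM in this assay, at which 1 of the 2 values shown sits. Compound 3 `O=C(CCCc1cn(CCOCCOCCOc2cc(O)c(C(=O)CCc3ccc(O)cc3)c(O)c2)nn1)OCn1cc(F)c(=O)[nH]c1=O` has not yet been measured in this assay. It differs from compound 2 in one place: hydrogen in place of 3,4,5-trihydroxy-6-(hydroxymethyl)oxan-2-yl on an oxygen on an aromatic ring. Going by the values given here, no step between two measured compounds is available here, and the two measured compounds differ from each other in more than one place, so only their two values can be compared. The expectation is that compound 3 moves out of the limit into a measurable range, a step of an at least 1.4-fold lower number from compound 2 to compound 3 (0.15 log units; that floor lies within the scatter) in this assay. Compound 3 is therefore estimated at 70000 nM, within a range from 25000 nM to 150000 nM.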

Compound 3, half-maximal inhibitory concentration: > 100000 nM
Compound 3 ended at the assay's limit; the forecaster's own chance of this, stated with the estimate: 35%; middle value at least 1.4-fold (0.15 log units) away from the limit.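

No step can be read from compound 2 to compound 3, because both results are limits of the assay and not numbers: the limit of > 100000 nM in this assay, at which 2 of the 3 values shown sit.

The compounds shown leave open whether hydrogen in place of 3,4,5-trihydroxy-6-(hydroxymethyl)oxan-2-yl on an oxygen on an aromatic ring changes cytotoxicity at all.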